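Trimming the Dipropylamino Group of a Corticotropin-Releasing Factor Ligand

A few compounds are considered here, and "the series" means these few. Any claim that something is new, unique, unknown or untested is made for them only; others in the source may bear on it.

Compound 1 `CCCN(CCC)c1c(C)nc(-c2c(C)cc(C)cc2OC)nc1OC`: 15 nM
Compound 2 `CCCc1nc(-c2c(C)cc(C)cc2OC)nc(OC)c1N(CCC)CCC`: 76 nM
Compound 3 `CCCN(CCC)c1c(CC(C)O)nc(-c2c(C)cc(C)cc2OC)nc1OC`: 1150 nM

In an in vitro assay on IMR-32 cells for displacement of a labelled ligand from corticotropin-releasing factor receptor 1 (Homo sapiens) (a higher number here means a weaker inhibitor, a lower number a stronger inhibitor), compound 1 gives 15 nM, the lowest number of the three measured compounds. The nearest is compound 2, reached by a 5.1-fold higher number from compound 1 to compound 2 (0.70 log units; beyond the scatter); the furthest is compound 3, reached by a 77-fold higher number from compound 1 to compound 3 (1.88 log units; beyond the scatter). Between those two, a 15-fold higher number from compound 2 to compound 3 (1.18 log units; beyond the scatter).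

Compound 4 `CCCNc1c(C)nc(-c2c(C)cc(C)cc2OC)nc1OC` has not yet been measured. It differs from compound 1 by hydrogen in place of propyl on a nitrogen on an aromatic ring, so the dipropylamino group becomes propylamino. None of the three measured steps touches this nitrogen; each alters the group on the saturated chain carbon bound to an aromatic carbon, and all made the number larger. Nothing measured here speaks directly to removing one propyl from the amine, so the expectation rests on the general observation that every departure from compound 1 so far has weakened binding. Compound 4 is therefore expected to show a modest rise, a 4.0-fold higher number from compound 1 to compound 4 (0.60 log units; beyond the scatter), with wide uncertainty. The estimate for compound 4 in this assay is 60 nM, within a range from 15 nM to 300 nM.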

Compound 4, inhibition constant: > 10000 nM
Compound 4: only a limit was reported (the forecaster's own chance of this, stated with the estimate: 3%); middle value at least 160-fold (2.22 log units) away from the limit.
By their numbers in this assay, from the lowest: compound 1; then compound 2; then compound 3. At a limit, above all of these: compound 4.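

In this assay the reading for compound 4 is a limit of the assay, not a number: the limit of > 10000 nM in this assay, at which 1 of the 4 values shown sits.

Going by these compounds alone, the step of an at least 660-fold higher number from compound 1 to compound 4 (2.82 log units; beyond the scatter) is the first look at the nitrogen on an aromatic ring, since compounds 2 and 3 differ from compound 1 only at the saturated chain carbon bound to an aromatic carbon. It shows that this nitrogen is also sensitive to change, and that binding in this series is lost when dipropylamino becomes propylamino, a change of a single propyl.

Still open, from the compounds shown here alone, is whether a butyl or a cyclopropylmethyl group in place of the removed propyl would bring binding back. Within the data shown here, with only this one step at the nitrogen, the effect of losing the propyl chain cannot be separated from the effect of the hydrogen that replaces it.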